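The compounds below may be only part of what the source reports. "The series", "measured", "known", "first", "only" and "open" are said of these compounds alone.

Of the compounds shown here, three have been measured in a functional assay on HTB-54 cells (Homo sapiens) for cytotoxicity, read by MTT assay, with a stated time of 72 h; a higher number here means a weaker inhibitor of growth, a lower number a stronger inhibitor of growth. Compound 1 `CC(C)COC(=O)Nc1ccc([Se][Se]c2ccc(NC(=O)OCC(C)C)cc2)cc1` gives 29000 nM, compound 3 `CCCCOC(=O)Nc1ccc([Se][Se]c2ccc(NC(=O)OCCCC)cc2)cc1` gives 35200 nM, and compound 2 `CCCOC(=O)Nc1ccc([Se]C#N)cc1` gives 28900 nM. Compound 2 holds the lowest of the three numbers, yet its gaps to compound 1 and to compound 3 both lie within the scatter, so no order among them can be read. Compound 4 `CCOC(=O)Nc1ccc([Se]C#N)cc1` has not yet been measured. It differs from compound 2 by hydrogen in place of methyl on a saturated chain carbon, two bonds along the chain from an oxygen next to a carbonyl group. Within the data shown here, no step between measured compounds shows what such a change does, so compound 4 is expected to stay close to compound 2. For compound 4 the expected step is a 1.0-fold higher number from compound 2 to compound 4 (0.00 log units; within the scatter), within the scatter. Compound 4 is therefore estimated at 29000 nM, in a range from 12000 nM to 70000 nM.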

Compound 4, concentration for 50% growth inhibition: 24900 nM
The estimate for compound 4 lay 1.2-fold (0.07 log units) above the measured number; measured number inside the range.
By their numbers in this assay, from the lowest: compounds 4, 2, 1 and 3 (each within the scatter of the next).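

In this assay, hydrogen in place of methyl at this position gives a 1.2-fold lower number from compound 2 to compound 4 (0.06 log units; within the scatter). Among these compounds, this first step at the position shows that going from propoxy to ethoxy leaves the number within the scatter, which the earlier compounds, joined by no step, could not show. No supporting measurement bears on this result. From the compounds shown here alone, whether a longer chain, an amine or a carboxylic acid on this carbon would move the number beyond the scatter remains open. So does whether the same change would behave alike on the core of compound 3.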